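The source may report more compounds than this note shows. Statements on the series, on what has been measured and on what is new or still open speak of the compounds shown alone.

Measured in a functional assay on A549 cells (Homo sapiens) for antiproliferative activity, read by MTT assay; on this read-out higher numbers stand for weaker inhibition and lower numbers for stronger inhibition:
Compound 1 `CCCOC(=O)N1CCCc2cc(S(=O)(=O)N3CC(c4ccccc4)NC3=O)ccc21`: 1030 nM
Compound 2 `O=C1NC(c2ccccc2)CN1S(=O)(=O)c1ccc2c(c1)CCCN2C(=O)C(F)(F)F`: > 20000 nM (a limit)

For compound 2 only a limit is known: the limit of > 20000 nM in this assay, at which 1 of the 2 values shown sits. Compound 3 `NC(=O)N1CCCc2cc(S(=O)(=O)N3CC(c4ccccc4)NC3=O)ccc21` carries amino in place of trifluoromethyl on a carbonyl carbon. Among the compounds with values here, the only measured step bearing on this, an at least 19-fold higher number from compound 1 to compound 2 (1.28 log units; beyond the scatter), was large and came with trifluoromethyl in place of propoxy on a carbonyl carbon. With trifluoromethyl gone, part of that step is expected to be recovered, towards lower numbers in this assay. The expected move is an at least 5.0-fold lower number from compound 2 to compound 3 (0.69 log units; beyond the scatter). The estimate for compound 3 is 4000 nM, with an expected range of 900 nM to 20000 nM.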

Compound 3, half-maximal inhibitory concentration: 2540 nM
The estimate for compound 3 lay 1.6-fold (0.20 log units) above the measured number, and the stated range covers the measured number.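

In this assay, the carbonyl carbon on the amide-type ring nitrogen does not need the propoxy group for the number to come back down: amino in place of trifluoromethyl gives a clear drop (an at least 7.8-fold lower number from compound 2 to compound 3 (0.89 log units; beyond the scatter)). Amino does not fully match propoxy, however (a 2.5-fold higher number from compound 1 to compound 3 (0.39 log units; beyond the scatter)). Going by these compounds, the true size of the first of these steps stays unknown, as compound 2 has only a limit: the limit of > 20000 nM in this assay, at which 1 of the 3 values shown sits.

On these data alone, it remains open whether a methyl group would behave like amino or trifluoromethyl. Also open, as far as these compounds go, is whether a longer chain such as butoxy would lower the number further than propoxy.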